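Lengthening the Sulfur Chain Once More

A few compounds are considered here, and "the series" means these few. Any claim that something is new, unique, unknown or untested is made for them only; others in the source may bear on it.

Measured in a functional assay on MOLT-3 cells (Homo sapiens) (a lower number here means a stronger inhibitor, a higher number a weaker inhibitor), so far
Compound 1 `CCSC[C@H](NC(C)=O)C(=O)CCl` gives 99900 nM
Compound 2 `CCCCCCCCSC[C@H](NC(C)=O)C(=O)CCl` gives 4100 nM

Compound 2 holds the lower of the two numbers and is the stronger inhibitor. Compound 3 `CCCCCCCCCCCCCCCSC[C@H](NC(C)=O)C(=O)CCl` differs from compound 2 by one change (heptyl in place of hydrogen on a saturated chain carbon, eight bonds along the chain from a sulfur) that lengthens the same chain. Within the data shown here, only one measured step bears on this, a similar lengthening (a 24-fold lower number from compound 1 to compound 2 (1.39 log units; beyond the scatter)) that was large and beyond the scatter. One step cannot show whether the gain continues, so a smaller step in the same direction is expected (a 3.4-fold lower number from compound 2 to compound 3 (0.53 log units; beyond the scatter)) in this assay as an estimate. For compound 3 the estimated value is 1200 nM with 200 nM to 8000 nM as the expected range.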

Compound 3, half-maximal inhibitory concentration: 8600 nM
Beside the measured number, compound 3's estimate is 7.2-fold (0.86 log units) below it; measured number above the stated range.
By their numbers in this assay, from the lowest: compound 2; then compound 3; then compound 1.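

Lengthening the sulfur chain does not keep lowering the number: in this assay the earlier gain, a 24-fold lower number from compound 1 to compound 2 (1.39 log units; beyond the scatter), reverses into a 2.1-fold higher number from compound 2 to compound 3 (0.32 log units; beyond the scatter). The response to chain length at this position is therefore not steady, and compound 2, with the middle chain of the three, gives the lowest number. No measurement shown explains this turn. Going by these compounds, whether a dodecyl chain would give a lower number than compound 2 stays open, as does the effect of a phenyl group in place of the chain.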